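Aryl extension on the ether side: solubility outlook

This account rests on a few compounds, and the source may have more. Where it says the series, first, only, none or still open, it means among the compounds named here.

Compound 1 `O=C(COc1ccc(OC(F)(F)F)cc1)N[C@@H]1COc2nc([N+](=O)[O-])cn2C1` stands second highest of three numbers in a physicochemical assay for solubility, read by HPLC, measured as kinetic solubility, at pH 7 (a lower number here means a less soluble compound, a higher number a more soluble compound), with 43 ug/mL. Its nearest neighbour is compound 3 `O=C(NCc1ccc(OC(F)(F)F)cc1)N[C@@H]1COc2nc([N+](=O)[O-])cn2C1`, which gives 32 ug/mL; the two lie within the scatter, so no order between them is claimed. Compound 2 `O=C(Nc1ccc(OC(F)(F)F)cc1)N[C@@H]1COc2nc([N+](=O)[O-])cn2C1` gives 93 ug/mL, beyond the scatter above compound 1. Among the measured compounds shown here, no pair of measured compounds differs in a single place, so there is no measured precedent for any single change.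

Compound 4 `O=C(COc1ccc(-c2ccc(OC(F)(F)F)cc2)cc1)N[C@@H]1COc2nc([N+](=O)[O-])cn2C1` differs from compound 1 in one place: 4-(trifluoromethoxy)phenyl in place of trifluoromethoxy on an aromatic carbon. None of compounds 1 to 3 carries an added aromatic ring, so the expectation rests on the change itself rather than on a measured step. In this assay the step of a 5.4-fold lower number from compound 1 to compound 4 (0.73 log units; beyond the scatter) is expected to run downward and beyond the scatter. Compound 4 is estimated at 8 ug/mL, with a range from 2 ug/mL to 25 ug/mL.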

Compound 4, solubility: 0.96 ug/mL
Beside the measured number, compound 4's estimate is 8.3-fold (0.92 log units) above it; the whole stated range lies above it.
By their numbers in this assay, from the lowest: compound 4; then compounds 3 and 1 (each within the scatter of the next); then compound 2.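

Among the compounds shown here, this is the first measured step, and it sits at a position that compounds 1 to 3 leave unvaried. In this assay, 4-(trifluoromethoxy)phenyl in place of trifluoromethoxy on an aromatic carbon gives a 45-fold lower number from compound 1 to compound 4 (1.65 log units; beyond the scatter) and is large, so this position is not neutral to this change. The entering group adds a six-membered aromatic ring of carbon only, with the same hydrogen-bond donor and acceptor counts and no net charge, and nothing at hand accounts for the size of the step.

With one step, the added ring cannot be separated from the trifluoromethoxy group it carries. Also open, as far as these compounds go, is how a morpholine or a carboxylic acid on the added ring would read in this assay and whether that ring would give a similar step on compound 2 or compound 3.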